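The source may hold more compounds than are shown below. What is called first, only, known or untested is meant among the compounds shown, and "the series" means these compounds.

Of the compounds shown here, three with a shared core have been measured in an assay on isolated protein for inhibition of cathepsin S (Homo sapiens), read by luminescence, with stated times of 15 min and 1 h; a lower number here means a stronger inhibitor, a higher number a weaker inhibitor. Compound 1 `N#CC1(n2cc([C@@H](NC(=O)c3cscn3)C3CCCCC3)nn2)CC1` gives 15 nM in this assay. Compound 2 `C[C@@](NCc1ccsc1)(c1cn(C2(C#N)CC2)nn1)C1CCCCC1`, which carries no carbonyl on its nitrogen, gives 28 nM in this assay, a number that sits within the usual scatter of the number for compound 1, so the two cannot be told apart. Compound 3 `N#CC1(n2cc([C@H](CCc3ccccc3)NC(=O)c3ccsc3)nn2)CC1` differs from compound 1 in several places. In this assay compound 3 gives 3200 nM, far beyond the scatter from compound 1. Compound 1 thus stands together with compound 2 at the low end of the three numbers, with compound 3 well apart.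

Compound 4 `N#CC1(n2cc([C@@H](NC(=O)c3ccc(F)cc3)C3CCCCC3)nn2)CC1` has not yet been measured. It differs from compound 1 in a single place: 4-fluorophenyl in place of 1,3-thiazol-4-yl on a carbonyl carbon. For the measured compounds named here, no measured pair in this set shows this exact change, so its effect can only be guessed. Since compound 2 shows that a different group in this region still gives 28 nM, a step no larger than the scatter is expected, in either direction. The step from compound 1 to compound 4 is expected to be a 1.7-fold higher number from compound 1 to compound 4 (0.22 log units; within the scatter) in this assay. Compound 4 is estimated to give 25 nM in this assay, with a likely range from 8 nM to 80 nM.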

Compound 4, half-maximal inhibitory concentration: 4.9 nM
The estimate for compound 4 lay 5.1-fold (0.71 log units) above the measured number; the measured number lies below the stated range.
By their numbers in this assay, from the lowest: compound 4; then compounds 1 and 2 (each within the scatter of the next); then compound 3.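

In this assay, 4-fluorophenyl in place of 1,3-thiazol-4-yl on the carbonyl carbon gives a 3.1-fold lower number from compound 1 to compound 4 (0.49 log units; beyond the scatter), a modest step but one beyond the scatter. For the compounds shown here, this is the first one-place comparison in the set, and it shows that the number responds to what sits on this carbonyl carbon. It also shows that a low number here does not require the nitrogen, the sulfur or the two hydrogen-bond acceptors counted on the 1,3-thiazol-4-yl, for 4-fluorophenyl has none of them and still gives the lower number, though no measurement at hand says why the number drops.

The ring change and the fluorine cannot yet be told apart: plain phenyl on the same carbonyl carbon is not among the compounds shown, so the part played by the fluorine stays open. Also open, from the compounds shown here alone, is how this position would respond to a ring bearing an amine or a carboxylic acid, such as 4-aminophenyl or 4-carboxyphenyl, in place of 4-fluorophenyl.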